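A few compounds are considered here, and "the series" means these few. Any claim that something is new, unique, unknown or untested is made for them only; others in the source may bear on it.

In an assay on isolated protein for inhibition of lysosomal alpha-glucosidase (Rattus norvegicus), read by colorimetric assay (on this read-out lower numbers stand for stronger inhibition and higher numbers for weaker inhibition), compound 1, with the structure `Cc1ccc([C@]2(CO)NC[C@@H](O)[C@@H]2O)cc1`, gives 43000 nM, the highest of the three numbers recorded and therefore the weakest inhibitor among them. Compound 2, `C[C@]1(CO)NC[C@@H](O)[C@@H]1O`, carries a methyl group on the shared core where compound 1 carries its aromatic group; in this assay compound 2 gives 830 nM. Compound 3, `Cc1ccc([C@@]2(CO)NC[C@H](O)[C@H]2O)cc1`, is the mirror image of compound 1; in this assay compound 3 gives 17000 nM. Among the compounds with values here, the only measured single-change step is a 2.5-fold lower number from compound 1 to compound 3 (0.40 log units; beyond the scatter), and it rests on (the fact that compounds 1 and 3 differ only in the configuration as drawn).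

Compound 4, `OC[C@@]1(c2ccccc2)NC[C@@H](O)[C@@H]1O`, is made from compound 1 by the change (hydrogen in place of methyl on an aromatic carbon). Within the data shown here, none of the measured steps touches a substituent on the aromatic ring, so no step bears directly on this change. The values of compound 1 and compound 2 show only that exchanging the whole aromatic group for a methyl group lowers the number greatly, which says little about trimming a single methyl from that ring. A small step is therefore expected in this assay, within or barely beyond the scatter, most likely toward a somewhat lower number, as a 1.7-fold lower number from compound 1 to compound 4 (0.24 log units; within the scatter). Compound 4 is estimated at 25000 nM, with a range from 8000 nM to 60000 nM.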

Compound 4, half-maximal inhibitory concentration: 904000 nM
The estimate for compound 4 lay 36-fold (1.56 log units) below the measured number; the measured number lies above the stated range.
By their numbers in this assay, from the lowest: compound 2; then compound 3; then compound 1; then compound 4.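

Replacing the methyl with hydrogen on an aromatic carbon, para to a group of 9 heavy atoms, is not the minor edit its size suggests: in this assay it brings a 21-fold higher number from compound 1 to compound 4 (1.32 log units; beyond the scatter), and compound 4 now has the highest number of the four compounds. This single-carbon change is a larger step than inverting every stereocentre, which gives a 2.5-fold lower number from compound 1 to compound 3 (0.40 log units; beyond the scatter), so for this aromatic group the methyl matters more to the read-out than the mirror-image change does. Nothing among the facts available accounts for the size of this step.

The compounds shown leave open whether methyl is a special choice at this place or whether other groups would serve as well, since an ethyl group, a methoxy group, a chlorine atom or an amine on the same aromatic carbon could each land on either side of compound 1. They also leave open whether hydrogen in place of methyl would bring a step of similar size when made on compound 3, the mirror-image compound.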